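The source may hold more compounds than are shown below. What is called first, only, known or untested is meant among the compounds shown, and "the series" means these compounds.

Measured in a functional assay on the whole organism (blood) with Rattus norvegicus as the target, with stated times of 24 h and 1 h, at a dose of 15 mg/kg by the intraperitoneal route; a lower number here means a weaker effect, a higher number a stronger effect of the compound at the dose given:
compound 1, `Cc1ncsc1C(=O)NCCC1CCN(S(=O)(=O)NC(=O)NC[C@@H]2C[C@@H]3C=C[C@@H]2C3)CC1`: 25%
compound 2, `CSc1ccc(C(F)(F)F)cc1C(=O)NCCC1CCN(S(=O)(=O)NC(=O)NC2CCCCC2)CC1`: 24%
compound 3, `CC#N.O=C(NC[C@@H]1C[C@@H]2CC[C@@H]1O2)NS(=O)(=O)N1CCC(CCNC(=O)c2nc3ccccc3s2)CC1`: 30%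

Compound 1 stands among three numbers that all lie within the scatter of one another: compound 2 is nearest, compound 3 furthest, neither gap beyond the scatter. Within the data shown here, no single-point step between measured compounds is available. Compound 4, `O=C(NC[C@@H]1C[C@@H]2C=C[C@@H]1C2)NS(=O)(=O)N1CCC(CCNC(=O)c2cccc3c2OCCO3)CC1`, is not yet measured in this assay. It differs from compound 1 as follows: 2,3-dihydro-1,4-benzodioxin-5-yl in place of 4-methyl-1,3-thiazol-5-yl on a carbonyl carbon. Across the measured set, compound 2 at 24% and compound 3 at 30% carry quite different groups on this carbonyl carbon and neither separates from compound 1 at 25% beyond the scatter. For compound 4 no step beyond the scatter is therefore expected in this assay, in either direction, the estimated step being a number 2 percentage points higher from compound 1 to compound 4 (within the scatter). Compound 4 is expected to give about 27%, within 15% to 40%.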

Compound 4, a percentage reported as activity, at one dose (the size of the read-out at that dose, not a potency): 40%
For compound 4 the middle estimate is 13 percentage points below the measured one, and the stated range covers the measured number.
By their numbers in this assay, from the lowest: compounds 2, 1, 3 and 4 (each within the scatter of the next, the first and the last beyond it).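

In this assay, the group on the carbonyl carbon can move the read-out: 2,3-dihydro-1,4-benzodioxin-5-yl in place of 4-methyl-1,3-thiazol-5-yl gives a number 15 percentage points higher from compound 1 to compound 4 (beyond the scatter). The change goes from 6 to 10 heavy atoms with equal hydrogen-bond donor and acceptor counts, so those counts do not separate the two groups. Nothing available explains the step.

Open, going by these compounds, is whether the oxygen atoms of the entering group matter or only its two-ring size. An unsubstituted phenyl or a naphthyl group on the same carbonyl carbon would address this.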